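Chalcone series on ovarian carcinoma cells: aryl swap

This account rests on a few compounds, and the source may have more. Where it says the series, first, only, none or still open, it means among the compounds named here.

Measured compounds in a functional assay on SK-OV-3 cells (Homo sapiens) for antiproliferative activity, read by MTT assay, with a stated time of 24 h; on this read-out lower numbers stand for stronger inhibition and higher numbers for weaker inhibition:
- compound 1, `COc1ccc(C(=O)/C=C/c2cccc(F)c2)c2c1C=CC(C)(C)O2`: > 10000 nM
- compound 2, `CCN(CC)c1ccc(/C=C/C(=O)c2ccc(OC)c3c2OC(C)(C)C=C3)cc1`: 610 nM
- compound 3, `COc1ccc(C(=O)/C=C/c2ccc(N(c3ccccc3)c3ccccc3)cc2)c2c1C=CC(C)(C)O2`: > 10000 nM

The value given for compound 1 in this assay is a limit of the assay, not a number. The same holds for compound 3, whose value is likewise a limit. Compound 1 thus stands at the limit of > 10000 nM in this assay, at which 2 of the 3 values shown sit, and only compound 2 yields a number.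

Compound 4, `COc1ccc(C(=O)/C=C/c2ccccc2Cl)c2c1C=CC(C)(C)O2`, is not yet measured in this assay. Its difference from compound 1 is 2-chlorophenyl in place of 3-fluorophenyl on a double-bonded chain carbon bound to a double-bonded chain carbon. For the measured compounds named here, nothing among the measured compounds shows what such a halogen swap on that aryl ring does; the only numeric value in the set belongs to compound 2, which carries a different group altogether.

With compound 1 sitting at a limit, the step that the limit leaves unreadable from compound 1 to compound 4 is expected to be small, most likely none beyond the scatter. For compound 4 the estimate in this assay is 15000 nM, spanning 3000 nM to 60000 nM, with a limit rather than a number the more probable outcome.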

Compound 4, half-maximal inhibitory concentration: > 10000 nM
Compound 4 was reported as a limit; the forecaster's own chance of this, stated with the estimate: 70%; the middle value is on the limit's open side.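

No step can be read from compound 1 to compound 4, since both values are limits of the assay: the limit of > 10000 nM in this assay, at which 3 of the 4 values shown sit.

Left open is what swapping 3-fluorophenyl for 2-chlorophenyl does in this assay; the only number shown belongs to compound 2, which carries a different group.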